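The compounds below may be only part of what the source reports. "The series", "measured", "known", "first", "only" and "open" are said of these compounds alone.

Compound 1, `O=C1COc2ccc(-c3cccc(NS(=O)(=O)c4ccc(F)cc4)c3)cc2N1c1ccc(Cl)cc1`, and compound 2, `O=C1COc2ccc(-c3cccc(NS(=O)(=O)c4ccc(F)cc4)c3)cc2N1c1ccccc1`, share one core and differ only by hydrogen in place of chloro on an aromatic carbon. In a functional assay on HepG2 cells (Homo sapiens) for antiproliferative activity, read by MTT assay, with a stated time of 72 h (a lower number here means a stronger inhibitor, a higher number a weaker inhibitor), compound 1 gives 27800 nM, and compound 2 gives 30300 nM, so that a 1.1-fold higher number from compound 1 to compound 2 (0.04 log units; within the scatter). Compound 3, `O=C1COc2ccc(-c3cnc(Cl)c(NS(=O)(=O)c4ccc(F)cc4)c3)cc2N1c1ccc(Cl)cc1`, carries a different core; how its core differs from that of compound 1 is not broken down here. In this assay compound 3 gives 33900 nM. Compound 4, `O=C1COc2ccc(-c3cnc(Cl)c(NS(=O)(=O)c4ccc(F)cc4)c3)cc2N1c1ccccc1`, differs from compound 3 by hydrogen in place of chloro on an aromatic carbon, placed exactly as in the step from compound 1 to compound 2, so it is the same change. Because a 1.1-fold higher number from compound 1 to compound 2 (0.04 log units; within the scatter), the step is expected to be a 1.1-fold higher number from compound 3 to compound 4 (0.03 log units; within the scatter). Compound 4 is therefore estimated to give 36000 nM, most likely between 20000 nM and 65000 nM.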

Compound 4, half-maximal inhibitory concentration: 35700 nM
Compound 4: middle estimate off by 1.0-fold (0.00 log units), on the high side; the range from low to high includes it.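

Replacing 4-chlorophenyl with phenyl gives a 1.1-fold higher number from compound 3 to compound 4 (0.02 log units; within the scatter) in this assay, and the two cores can be compared directly: the same change on two cores in this assay, a 1.1-fold higher number (0.04 log units; within the scatter) from compound 1 to compound 2 and a 1.1-fold higher number (0.02 log units; within the scatter) from compound 3 to compound 4, 1.0-fold (0.01 log units) apart, within the scatter of two such steps. The change therefore carries over between these two cores, but what carries over is a step too small to separate from the ordinary scatter of repeated measurements, so neither core shows a clear effect of the chloro group. Two cores say nothing about further cores, and such small steps do not show whether a change with a large effect would carry over equally well.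

On these data alone, only chloro and hydrogen appear at this place on the ring, so the outcome with an amine, a methoxy group or a carboxylic acid there stays open. As far as these compounds go, whether the change behaves the same way in other cell lines or assays also stays open.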